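Sulfonamide to amine at the piperidine side chain

This account rests on a few compounds, and the source may have more. Where it says the series, first, only, none or still open, it means among the compounds named here.

Measured compounds:
Compound 1 `O=S(=O)(NCC1CCN(CCCc2c[nH]c3ccc(-n4cnnc4)cc23)CC1)c1ccccc1`: 73%
Compound 2 `C[C@@H](NC1CCN(CCCc2c[nH]c3ccc(-n4cnnc4)cc23)CC1)c1ccccc1`: 90%
Compound 3 `CN(Cc1ccccc1)CC1CCN(CCCc2c[nH]c3ccc(-n4cnnc4)cc23)CC1`: 93%

In a functional assay on CHO cells for activation of 5-hydroxytryptamine receptor 1D (Homo sapiens), read by GTPgammaS binding (on this read-out higher numbers stand for larger maximal responses and lower numbers for smaller maximal responses), compound 1 gives 73%, the lowest of the three numbers. Compound 2 gives 90% and compound 3 gives 93%; the two steps from compound 1 are a number 17 percentage points higher from compound 1 to compound 2 (beyond the scatter) and a number 20 percentage points higher from compound 1 to compound 3 (beyond the scatter), both beyond the scatter, whereas a number 3 percentage points higher from compound 2 to compound 3 (within the scatter) is within it. In both steps a (phenylsulfonyl)amino group gives way to a basic amine carrying a phenyl-bearing substituent.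

Compound 4 `CC(=O)Nc1ccc([C@H](C)NCC2CCN(CCCc3c[nH]c4ccc(-n5cnnc5)cc34)CC2)cc1` is not yet measured in this assay. It differs from compound 1 as follows: 1-(4-acetamidophenyl)ethyl in place of phenylsulfonyl on an amine nitrogen. The change again removes the phenylsulfonyl and leaves an amine bearing a 1-arylethyl group on the saturated chain carbon, so the steps from compound 1 to compound 2 and from compound 1 to compound 3 bear on it; both were modest rises beyond the scatter. Going by the values given here, the acetamido group has no measured counterpart, so its effect is unknown. A rise of similar size is therefore expected, a number 15 percentage points higher from compound 1 to compound 4 (beyond the scatter), and compound 4 is estimated at 88%, within 74% to 100%.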

Compound 4, largest response reached (reported as efficacy), in percent of the reference or control that the assay uses: 99%
For compound 4 the middle estimate is 11 percentage points below the measured one; measured number inside the range.
By their numbers in this assay, from the lowest: compound 1; then compounds 2, 3 and 4 (each within the scatter of the next).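

In this assay, going by these compounds alone, the step from phenylsulfonyl to 1-(4-acetamidophenyl)ethyl is a number 26 percentage points higher from compound 1 to compound 4 (beyond the scatter) and is the first in this set made on the amine nitrogen alone, with the saturated chain carbon kept in place. Compounds 2 and 3 had already pointed the same way, but compound 2 also differs from compound 1 in the link to the saturated ring, and compound 3 carries a methyl on its nitrogen, so neither isolates the sulfonyl group as compound 4 does. The result also shows that an acetamido group on the aryl ring and a defined stereocentre on the new substituent are compatible with a large maximal response at this position, although nothing available explains the rise.

The compounds shown leave open how much of the step belongs to the acetamido group, since a plain 1-phenylethyl on this same amine nitrogen is not among them, and a methoxy group or a carboxylic acid in place of the acetamido group would test that substituent further. They also leave open what the opposite configuration at the stereocentre would give, and whether a benzyl group on this nitrogen would serve as well as 1-(4-acetamidophenyl)ethyl.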